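From Methylamide to Pyrrolidine Amide: An Expected Reading

This account rests on a few compounds, and the source may have more. Where it says the series, first, only, none or still open, it means among the compounds named here.

The measured compounds:
compound 1 `CNC(=O)CC1CCc2cc(OC)c(OC)cc21`, 29%
compound 2 `CCNC(=O)CC1CCc2cc(OC)c(OC)cc21`, 26.1%
compound 3 `COc1cc2c(cc1OC)C(CC(=O)NC1CCCC1)CC2`, 43.5%

These three were tested in a functional assay on the whole organism (strain Wistar) for inhibition, with Rattus norvegicus as the target, read by paw edema, with stated times of 60 min and 3 h, at a dose of 100 mg/kg by the oral route; a lower number here means less inhibition, a higher number more inhibition at the dose given (going by the name of the read-out). Compound 1 stands second highest of the three numbers, close to compound 2, the step of a number 2.9 percentage points lower from compound 1 to compound 2 (within the scatter) lying within the scatter, and furthest from compound 3, the step of a number 14.5 percentage points higher from compound 1 to compound 3 (beyond the scatter) being modest but beyond the scatter. The same direction is seen in a number 17.4 percentage points higher from compound 2 to compound 3 (beyond the scatter).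

Compound 4 `COc1cc2c(cc1OC)C(CC(=O)N1CCCC1)CC2` has not been measured. It differs from compound 1 as follows: pyrrolidin-1-yl in place of methylamino on a carbonyl carbon.

Among the measured compounds shown here, none of the measured steps exchanges the amide hydrogen itself; the two steps that widen the group on the amide nitrogen, from methyl or ethyl to cyclopentyl, each gave a modest gain, while the small chain extension gave none beyond the scatter. The ring entering in compound 4 is closed onto the nitrogen rather than hung from it, so these steps bear on it only loosely. Compound 4 is therefore expected to sit near compound 1, with a step of a number 4 percentage points higher from compound 1 to compound 4 (within the scatter) that is not expected to exceed the scatter. The estimate for compound 4 is 33%, with a range from 18% to 48%.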

Compound 4, a percentage reported as inhibition, in the whole organism at one dose (the size of the read-out at that dose, not a potency): 26.1%
Estimate against measurement, compound 4: 6.9 percentage points above; the range from low to high includes it.
By their numbers in this assay, from the lowest: compounds 2, 4 and 1 (each within the scatter of the next); then compound 3.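

In this assay, pyrrolidin-1-yl in place of methylamino on the carbonyl carbon, which removes the one hydrogen-bond donor of that group, gave a number 2.9 percentage points lower from compound 1 to compound 4 (within the scatter), and in place of ethylamino it gave no change at the digits printed from compound 2 to compound 4 (within the scatter). A five-membered ring on the amide nitrogen therefore does not by itself bring the higher number: with the ring closed onto the nitrogen instead of hung from it as cyclopentylamino, the result was a number 17.4 percentage points lower from compound 3 to compound 4 (beyond the scatter), and among these four compounds only compound 3 stands apart. Nothing shown here accounts for the difference between these two rings.

Going by these compounds, whether cyclobutylamino or cyclohexylamino would keep the number of compound 3 remains open. So does the result for a cyclopentylamino group carrying an added methyl on its nitrogen, which would keep the ring but lose the amide hydrogen.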